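Lengthening the amine chain on a furan-bearing core

The compounds below may be only part of what the source reports. "The series", "measured", "known", "first", "only" and "open" are said of these compounds alone.

Compound 1 `CCCn1cnc2c(NCCCc3ccccc3)ncnc21`: > 30000 nM
Compound 2 `CCCn1c(Br)nc2c(NCCCc3ccccc3)ncnc21`: 1760 nM
Compound 3 `CCCn1c(-c2ccco2)nc2c(NCc3ccccc3)ncnc21`: 1760 nM

In a functional assay on CHO cells for antagonist activity at adenosine receptor A2b (Homo sapiens) (a higher number here means a weaker inhibitor, a lower number a stronger inhibitor), compound 1 gives only a limit, > 30000 nM (the limit of > 30000 nM in this assay, at which 1 of the 3 values shown sits). Compound 3 stands level with compound 2 in this assay, the two values being the same at the digits shown. Compound 4 `CCCn1c(-c2ccco2)nc2c(NCCCc3ccccc3)ncnc21` differs from compound 3 by phenethyl in place of phenyl on a saturated chain carbon bound to a nitrogen on an aromatic ring. For the measured compounds named here, the only measured step, an at least 17-fold lower number from compound 1 to compound 2 (1.23 log units; beyond the scatter), concerns a different position and does not bear on this chain change; no measured pair isolates it. Compound 4 is therefore expected near compound 3, with a 1.2-fold lower number from compound 3 to compound 4 (0.07 log units; within the scatter) lying within the scatter. The estimate for compound 4 is 1500 nM, with a range from 400 nM to 6000 nM.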

Compound 4, inhibition constant: 1870 nM
Compound 4: middle estimate off by 1.2-fold (0.10 log units), on the low side; the range from low to high includes it.
By their numbers in this assay, from the lowest: compounds 2, 3 and 4 (each within the scatter of the next). At a limit, above all of these: compound 1.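

Changing benzyl to 3-phenylpropyl with furan-2-yl kept in place gives a 1.1-fold higher number from compound 3 to compound 4 (0.03 log units; within the scatter), so in this assay these two chain lengths cannot be told apart. Furan-2-yl in place of bromo gives a 1.1-fold higher number from compound 2 to compound 4 (0.03 log units; within the scatter), so these two groups cannot be told apart on this core either. Furan-2-yl in place of hydrogen gives an at least 16-fold lower number from compound 1 to compound 4 (1.20 log units; beyond the scatter), a step that starts from a limit for compound 1: the limit of > 30000 nM in this assay, at which 1 of the 4 values shown sits.

Still open, going by these compounds, is whether a longer chain than 3-phenylpropyl, or an amine or a carboxylic acid in place of furan-2-yl, would move the number beyond the scatter.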